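Swapping Methyl for Chloro on a Nicotinic Receptor Ligand

The compounds below may be only part of what the source reports. "The series", "measured", "known", "first", "only" and "open" are said of these compounds alone.

In an assay on HEK293 cells for displacement of a labelled ligand from Neuronal acetylcholine receptor; alpha3/beta4 (Homo sapiens) (on this read-out lower numbers stand for stronger inhibition and higher numbers for weaker inhibition), compound 2 `Cc1ccc(Nc2cncc(N3CC4CC(C3)N4)c2)cc1` gives 1.4 nM. Compound 1 `COc1ccc(Nc2cncc(N3CC4CC(C3)N4)c2)cc1` gives 2.2 nM, and the step of a 1.6-fold lower number from compound 1 to compound 2 (0.20 log units; within the scatter) shows that replacing methoxy with methyl moved the number only within the scatter. Compound 3 `O=[N+]([O-])c1ccc(Nc2ccc(N3CC4CC(C3)N4)cn2)cc1`, which carries a nitro group and has its core arranged differently, gives 25 nM, a gap from compound 2 that lies beyond the scatter. Compound 4 `Clc1ccc(Nc2cncc(N3CC4CC(C3)N4)c2)cc1` differs from compound 2 by chloro in place of methyl on an aromatic carbon. Among the measured compounds shown here, no measured step swaps methyl for chloro, and the only step at this position, a 1.6-fold lower number from compound 1 to compound 2 (0.20 log units; within the scatter), stayed within the scatter. The expected value for compound 4 in this assay is therefore 2 nM, with a range from 0.7 nM to 6 nM. The estimated step of a 1.4-fold higher number from compound 2 to compound 4 (0.15 log units; within the scatter) is expected to stay within the scatter.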

Compound 4, inhibition constant: 1.2 nM
For compound 4 the middle estimate is 1.7-fold (0.22 log units) above the measured one; the measured number falls inside the stated range.
By their numbers in this assay, from the lowest: compounds 4, 2 and 1 (each within the scatter of the next); then compound 3.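

In this assay the change from 4-methylphenyl to 4-chlorophenyl gives a 1.2-fold lower number from compound 2 to compound 4 (0.07 log units; within the scatter) and chloro in place of methoxy gives a 1.8-fold lower number from compound 1 to compound 4 (0.26 log units; within the scatter) on the same aromatic carbon. Methyl, methoxy and chloro, para to a large group, therefore all lie within the scatter of one another, so this position has now taken three different groups with no clear change in the number. No measured evidence is available to explain why these three groups read alike. On these data alone, whether an amine, a carboxylic acid or a longer chain here would stay equally close remains open.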